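The source may report more compounds than this note shows. Statements on the series, on what has been measured and on what is new or still open speak of the compounds shown alone.

Compound 1 `COc1ccc2c(=O)c(/C=C/C(=O)Nc3ccc(Cl)cc3)coc2c1` gives only a limit of the assay in a functional assay (QGY7701 cells, Homo sapiens) for inhibition, read by MTT assay, with a stated time of 48 h (a higher number here means a weaker inhibitor, a lower number a stronger inhibitor), namely > 100000 nM. Compound 2 `COc1ccc(CNC(=O)/C=C/c2coc3cc(OC)ccc3c2=O)cc1` gives 15700 nM. Compound 3 `COc1ccc2c(=O)c(/C=C/C(=O)Nc3ccccc3OC)coc2c1` gives 17600 nM.

Compound 3 carries the highest of the two proper numbers, yet the step between the two is a 1.1-fold higher number from compound 2 to compound 3 (0.05 log units; within the scatter), so they cannot be told apart. Compound 4 `COc1ccc2c(=O)c(/C=C/C(=O)Nc3ccc(F)cc3)coc2c1` differs from compound 3 in one place: 4-fluorophenyl in place of 2-methoxyphenyl on an amide-type nitrogen. The step that bears on this is the one from the 4-chlorophenyl amide to the 2-methoxyphenyl amide, an at least 5.6-fold lower number from compound 1 to compound 3 (0.75 log units; beyond the scatter), alongside the parallel step an at least 6.3-fold lower number from compound 1 to compound 2 (0.80 log units; beyond the scatter); both show that moving away from a 4-halophenyl group on the amide nitrogen lowers the number. Compound 4 returns to a 4-halophenyl group, so the step of a 3.4-fold higher number from compound 3 to compound 4 (0.53 log units; beyond the scatter) is expected to run the other way and raise the number, possibly back to the limit (the limit of > 100000 nM in this assay, at which 1 of the 3 values shown sits). Compound 4 is therefore estimated at 60000 nM, with a range from 15000 nM to 200000 nM.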

Compound 4, half-maximal inhibitory concentration: > 100000 nM
Compound 4: a limit, no number; the forecaster's own chance of this, stated with the estimate: 40%; at least 1.6-fold (0.22 log units) between middle value and limit.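

Putting 4-fluorophenyl on the amide-type nitrogen gives an at least 5.6-fold higher number from compound 3 to compound 4 (0.75 log units; beyond the scatter) and an at least 6.3-fold higher number from compound 2 to compound 4 (0.80 log units; beyond the scatter) in this assay. Until now, only the 4-chlorophenyl amide had reached the limit, so that result could have been special to chloro; with fluoro in place of chloro the compound stays at the limit, and among the compounds shown, only the two 4-halophenyl amides do so. The step from compound 1 to compound 4 cannot be read, and the two halogens stay unranked, with both compounds resting on a limit: the limit of > 100000 nM in this assay, at which 2 of the 4 values shown sit.

The compounds shown leave open whether the halogen itself matters or only the absence of a methoxy group. A plain phenyl or a 4-methoxyphenyl on the amide-type nitrogen would help to separate these two readings.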